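A few compounds are considered here, and "the series" means these few. Any claim that something is new, unique, unknown or untested is made for them only; others in the source may bear on it.

Compound 3 `Cc1cc(C)c(CN2CCc3c(Cl)cc([C@@H](CO)[C@@H]4CCOC4)c(Cl)c3C2=O)c(=O)[nH]1` is the weakest of the two compounds that have a single number in an assay for inhibition of histone-lysine N-methyltransferase EZH2 variant Y641N (Homo sapiens), read by scintillation counting, with a stated time of 60 min, in the presence of a further agent that is not named here; on this read-out higher numbers stand for weaker inhibition and lower numbers for stronger inhibition: compound 3 gives 1260 nM. Its closest relative, compound 1 `Cc1cc(C)c(CN2CCc3c(Cl)cc([C@H](CO)[C@H]4CCCO4)c(Cl)c3C2=O)c(=O)[nH]1`, differs only in how the five-membered oxygen-containing ring is attached, and in this assay compound 1 gives 8 nM. That single change produced a 160-fold higher number from compound 1 to compound 3 (2.20 log units; beyond the scatter). A third member of the series, compound 2 `COC(c1cc(Cl)c2c(c1Cl)C(=O)N(Cc1c(C)cc(C)[nH]c1=O)CC2)C1CCS(=O)(=O)CC1`, has been tested more than once, and in this assay compound 2 gives 93 nM; 0.35 nM (2 entries), so the spread of repeated tests the several entries of compound 2 in this assay, 93 nM; 0.35 nM (2 entries) shows that this read-out can wander widely even for one substance.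

Compound 4 `Cc1cc(C)c(CN2CCc3c(Cl)cc([C@H](C)CO)c(Cl)c3C2=O)c(=O)[nH]1` has not yet been tested. It is made from compound 3 by a single change: methyl in place of oxolan-3-yl on a saturated chain carbon bound to an aromatic carbon and a saturated chain carbon. Going by the values given here, no measured step in this set removes the ring altogether, so the only guidance is indirect: the swap from compound 1 to compound 3 shows that the shape of this group matters greatly, and the scatter seen for compound 2 warns against a narrow guess. Since a small methyl neither matches the ring of compound 1 nor that of compound 3, compound 4 is expected to show a 21-fold lower number from compound 3 to compound 4 (1.32 log units; beyond the scatter) in this assay, with compound 4 estimated at 60 nM, plausibly between 4 nM and 1000 nM.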

Compound 4, inhibition constant: 17 nM
Estimate against measurement, compound 4: 3.5-fold (0.55 log units) above, and the stated range covers the measured number.
By their numbers in this assay, from the lowest: compound 1; then compound 4; then compound 3.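

At this saturated chain carbon, bound to an aromatic carbon and a saturated chain carbon, the oxolan-3-yl ring is not needed for inhibition in this assay, and replacing it with methyl gives a 74-fold lower number from compound 3 to compound 4 (1.87 log units; beyond the scatter). The earlier swap of one ring for another could not show whether the weak result came from a poorly suited ring or from losing something the other ring provided, but this large step points to the oxolan-3-yl ring itself as the liability, while the ring-bearing group of the stronger compound adds little over the smaller group, with a 2.1-fold higher number from compound 1 to compound 4 (0.33 log units; beyond the scatter). These sizes should still be read with some care, as repeat tests of a single substance in this read-out can lie far apart: the several entries of compound 2 in this assay, 93 nM; 0.35 nM (2 entries)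

From the compounds shown here alone, it remains open how inhibition would respond to other groups at this carbon, such as ethyl, a longer chain or an amine, and so whether the trend depends on size alone or on the kind of group. Also open, going by these compounds, is how the opposite spatial arrangement at this carbon would compare with the methyl-bearing compound 4.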